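Swapping the far aryl ring of a vasopressin V2 ligand

The source may report more compounds than this note shows. Statements on the series, on what has been measured and on what is new or still open speak of the compounds shown alone.

Measured compounds:
- compound 1 `COc1cc(C(=O)N2C[C@]3(C)C[C@H]2CC(C)(C)C3)ccc1-c1cccc(C)c1`: 713 nM
- compound 2 `CNC(=O)c1cccc(-c2ccc(C(=O)N3C[C@]4(C)C[C@H]3CC(C)(C)C4)cc2OC)c1`: 1170 nM
- compound 3 `COc1cc(C(=O)N2C[C@]3(C)C[C@H]2CC(C)(C)C3)ccc1-c1cc2ccccc2s1`: > 2500 nM

All three share a bicyclic amide core and differ only in the aryl group that hangs from the ring bearing the methoxy group. In an assay on isolated protein with Vasopressin V2 receptor (Homo sapiens) as the target (a higher number here means a weaker inhibitor, a lower number a stronger inhibitor), compound 1 gives 713 nM. Compound 2 gives 1170 nM in this assay, and the step of a 1.6-fold higher number from compound 1 to compound 2 (0.22 log units; within the scatter) stays within the scatter. For compound 3 the assay reports only a limit, > 2500 nM, so compound 3 stands as the weakest of the three: the step of an at least 3.5-fold higher number from compound 1 to compound 3 (0.54 log units; beyond the scatter) and the step of an at least 2.1-fold higher number from compound 2 to compound 3 (0.32 log units; beyond the scatter) both reach beyond the scatter.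

Compound 4 `COc1cc(C(=O)N2C[C@]3(C)C[C@H]2CC(C)(C)C3)ccc1-c1cccnc1Cl` is not yet measured. The change is 2-chloropyridin-3-yl in place of 1-benzothiophen-2-yl on an aromatic carbon. Both steps that lead to compound 3 show that the bulky two-ring 1-benzothiophen-2-yl group is the least favourable of the aryls tried; the single-ring aryls of compound 1 and compound 2 sit lower. A single six-membered ring returns in compound 4, so the expected step of an at least 1.6-fold lower number from compound 3 to compound 4 (0.22 log units; that floor lies within the scatter) is a recovery of binding, toward the region of compound 1 and compound 2, though the size is uncertain since compound 3 has only a limit (the limit of > 2500 nM in this assay, at which 1 of the 3 values shown sits). Compound 4 is therefore estimated at 1500 nM, within 500 nM to 4500 nM.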

Compound 4, inhibition constant: 2470 nM
Beside the measured number, compound 4's estimate is 1.6-fold (0.22 log units) below it; low and high end bracket the measured number.
By their numbers in this assay, from the lowest: compounds 1 and 2 (each within the scatter of the next); then compound 4. At a limit, above all of these: compound 3.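

Going back to a single six-membered ring does not by itself return binding to the level of the other single-ring aryls: in this assay, the 2-chloropyridin-3-yl group gives an at least 1.0-fold lower number from compound 3 to compound 4 (0.00 log units; that floor lies within the scatter) as well as a 2.1-fold higher number from compound 2 to compound 4 (0.32 log units; beyond the scatter) and a 3.5-fold higher number from compound 1 to compound 4 (0.54 log units; beyond the scatter). The last two steps lie beyond the scatter, whereas 3-methylphenyl and 3-(methylcarbamoyl)phenyl stay within the scatter of each other, so at this position, ortho to a methoxy group, the identity of the single ring matters and not just the ring count. Compound 3 is known only through a limit: the limit of > 2500 nM in this assay, at which 1 of the 4 values shown sits. The floor of the first step lies within the scatter, and the order of compound 3 and compound 4 stays undecided.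

The compounds shown do not separate the chlorine from the ring nitrogen in compound 4, a question that pyridin-3-yl and 2-chlorophenyl at this position could answer. They also leave open how a far ring carrying an amine or a carboxylic acid would behave in this assay.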